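The source may hold more compounds than are shown below. What is called first, only, known or untested is meant among the compounds shown, and "the series" means these compounds.

Measured compounds:
- compound 1 `COc1ccc(/C=C/C(=O)c2c(C)cc(O)c(C(=O)/C=C/c3ccc(OC)cc3)c2-c2ccc(OCc3ccccc3)cc2)cc1` — in a functional assay on MDA-MB-231 cells (Homo sapiens) for cytotoxicity, read by MTT assay, with a stated time of 24 h (a lower number here means a stronger inhibitor, a higher number a weaker inhibitor), compound 1 gives 12000 nM
- compound 2 `Cc1cc(O)c(C(=O)/C=C/c2ccc(Cl)cc2)c(-c2ccc(Br)cc2)c1C(=O)/C=C/c1ccc(Cl)cc1` — in this assay compound 2 gives 15000 nM
- compound 3 `Cc1cc(O)c(C(=O)/C=C/c2ccc3ccccc3c2)c(-c2ccc(Cl)cc2)c1C(=O)/C=C/c1ccc2ccccc2c1` — in this assay compound 3 gives "not active" (no number reported), without a number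

Compound 3 therefore has no position on the numerical scale: the two compounds that do carry numbers, compound 1 and compound 2, both sit in the weak region, and their two values lie within the scatter of each other, so neither can be ordered against the other. Compound 3 stands below both only in the sense that no half-maximal inhibitory concentration could be assigned to it.

The next compound is compound 4 `Cc1cc(O)c(C(=O)/C=C/c2ccc3ccccc3c2)c(-c2ccccc2)c1C(=O)/C=C/c1ccc2ccccc2c1`. The change from compound 3 is hydrogen in place of chloro on an aromatic carbon. For the measured compounds named here, no measured pair in this set isolates this change, so no step size can be read from the data. Given that compound 3 gave no number at all, the expectation is that the removal of the chloro does not move compound 4 out of the weak region; the direction, if any, is uncertain, and a step beyond the scatter is not anticipated. It is also plausible that compound 4 returns only a limit rather than a number.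

Compound 4 is expected to give about 25000 nM in this assay, with a range from 8000 nM to 80000 nM.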

Compound 4, half-maximal inhibitory concentration: 30000 nM
Compound 4: the middle estimate sits 1.2-fold (0.08 log units) below what was measured; low and high end bracket the measured number.
By their numbers in this assay, from the lowest: compounds 1, 2 and 4 (each within the scatter of the next, the first and the last beyond it).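

In this assay compound 3 carries no number and compound 4 gives 30000 nM, so no step can be read between them. The compounds shown leave open whether the change from 4-chlorophenyl to phenyl shifts the half-maximal inhibitory concentration at all. No independent evidence bears on this result.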